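Aryl variation on the triazole of a spirooxindole series

The compounds below may be only part of what the source reports. "The series", "measured", "known", "first", "only" and "open" are said of these compounds alone.

The three measured compounds share one spiro core and differ only in the aryl group on the triazole nitrogen. Compound 1 `CCOc1ccc(-n2nncc2CN2C(=O)C3(C(C#N)=C(N)Oc4c(N)cc5nc6ccccc6nc5c43)c3ccccc32)cc1` carries a 4-ethoxyphenyl there. In a functional assay on HepG2 cells (Homo sapiens) for antiproliferative activity, read by MTT assay, with a stated time of 48 h (a lower number here means a stronger inhibitor, a higher number a weaker inhibitor), compound 1 reaches only the limit of the assay, > 50000 nM, and not a number. Compound 2 `N#CC1=C(N)Oc2c(N)cc3nc4ccccc4nc3c2C12C(=O)N(Cc1cnnn1-c1ccc(Cl)cc1Cl)c1ccccc12` carries a 2,4-dichlorophenyl. In this assay compound 2 likewise stops at the limit, > 50000 nM. For the measured compounds named here, compound 3 `COc1ccc(OC)c(-n2nncc2CN2C(=O)C3(C(C#N)=C(N)Oc4c(N)cc5nc6ccccc6nc5c43)c3ccccc32)c1` carries a 2,5-dimethoxyphenyl, and in this assay compound 3 gives 45100 nM, the only actual number among the three. The step of an at least 1.1-fold lower number from compound 1 to compound 3 (0.04 log units; that floor lies within the scatter) and the step of an at least 1.1-fold lower number from compound 2 to compound 3 (0.04 log units; that floor lies within the scatter) are therefore readable only as floors, while the step that the two limits leave unreadable from compound 1 to compound 2 cannot be read at all. The picture is set by the limit of > 50000 nM in this assay, at which 2 of the 3 values shown sit.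

Compound 4 `Cc1cc(C)c(-n2nncc2CN2C(=O)C3(C(C#N)=C(N)Oc4c(N)cc5nc6ccccc6nc5c43)c3ccccc32)c(C)c1` brings the next change: 2,4,6-trimethylphenyl in place of 2,5-dimethoxyphenyl on an aromatic nitrogen. Since all three aryl groups tried so far leave the number at or just under the limit, no step beyond the scatter is expected, and a 1.1-fold higher number from compound 3 to compound 4 (0.04 log units; within the scatter) is the estimated outcome. For compound 4 the expected value in this assay is 50000 nM, within 20000 nM to 120000 nM.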

Compound 4, half-maximal inhibitory concentration: 48100 nM
Compound 4: the middle estimate sits 1.0-fold (0.02 log units) above what was measured, and the stated range covers the measured number.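

In this assay, compound 4 adds a second actual number to the series, and a 1.1-fold higher number from compound 3 to compound 4 (0.03 log units; within the scatter) shows that this position tolerates the loss of the 2 hydrogen-bond acceptors of 2,5-dimethoxyphenyl, with 2,4,6-trimethylphenyl in their place, without any change beyond the scatter. Against the two compounds that stop at the limit, only floors can be read, an at least 1.0-fold lower number from compound 2 to compound 4 (0.01 log units; that floor lies within the scatter) and an at least 1.0-fold lower number from compound 1 to compound 4 (0.01 log units; that floor lies within the scatter), so compound 4 is not separated from either of them. The series therefore still shows no aryl group on this aromatic nitrogen that moves the number clearly, and what it can show about this position remains bounded by a single ceiling: the limit of > 50000 nM in this assay, at which 2 of the 4 values shown sit.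

The compounds shown leave open whether a different kind of group on this aromatic nitrogen, such as a phenyl ring carrying a carboxylic acid or a dimethylamino group, would bring the number well under the limit. They also leave open whether a change elsewhere on the shared core, such as an amide in place of the nitrile, would matter more than any change to this aryl group.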